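Swapping a Methylphenyl for a Hydroxyphenyl on a Triazole

The source may hold more compounds than are shown below. What is called first, only, known or untested is meant among the compounds shown, and "the series" means these compounds.

Of the compounds shown here, three have so far been tested in a functional assay on CFPAC-1 cells (Homo sapiens) for antiproliferative activity, read by MTT assay, with a stated time of 72 h; on this read-out higher numbers stand for weaker inhibition and lower numbers for stronger inhibition. Compound 1 `O=C1O[C@H]([C@@H](O)Cn2cc(-c3ccc(Br)cc3)nn2)C(OCc2ccccc2)=C1OCc1ccccc1` gives 5830 nM in this assay. Compound 2 `Cc1ccc(-c2cn(C/C=C3\OC(=O)C(OCc4ccccc4)=C3OCc3ccccc3)nn2)cc1` reaches only the limit of this assay, > 100000 nM, so no number is known for it. Compound 3 `CC(C)(C)OC(=O)N1CCN(C(=S)SCc2cn(C[C@H](O)[C@H]3OC(=O)C(OCc4ccccc4)=C3OCc3ccccc3)nn2)CC1` likewise sits at the limit, > 100000 nM. For the measured compounds named here, compound 2 therefore stands at the limit of > 100000 nM in this assay, at which 2 of the 3 values shown sit, among the weakest readings recorded here, and no two measured compounds differ in a single place, so no measured step is available for guidance.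

Compound 4 `O=C1O/C(=C\Cn2cc(-c3cccc(O)c3)nn2)C(OCc2ccccc2)=C1OCc1ccccc1` has not yet been measured. It differs from compound 2 in one respect: 3-hydroxyphenyl in place of 4-methylphenyl on an aromatic carbon. Going by the values given here, the measured compounds say nothing about what this exchange does, and the only numeric value, that of compound 1, belongs to a compound with a differently built core.

The step from compound 2 to compound 4 is therefore expected to be modest, an at least 1.6-fold lower number from compound 2 to compound 4 (0.22 log units; that floor lies within the scatter), a slight move toward stronger inhibition that may not exceed the usual scatter. Compound 4 is estimated at about 60000 nM in this assay, within a range from 15000 nM to 200000 nM, and it may well again reach only the limit.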

Compound 4, half-maximal inhibitory concentration: 33700 nM
Compound 4: middle estimate off by 1.8-fold (0.25 log units), on the high side, and the stated range covers the measured number.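

The earlier compounds shown here offered no measured step, and this pair supplies the first: in this assay, placing 3-hydroxyphenyl where 4-methylphenyl stood, on an aromatic carbon of the five-membered aromatic ring with 3 nitrogen, gives an at least 2.9-fold lower number from compound 2 to compound 4 (0.47 log units; beyond the scatter). With the rest of the structure unchanged, this single exchange turns a reading with no number into a measurable one, so the group at this position does affect the result, and compound 4 gives 33700 nM. The reading for compound 2 is a limit and not a number, so the step has only a lower bound and its true size is unknown: the limit of > 100000 nM in this assay, at which 2 of the 4 values shown sit.

This exchange alters both the group on the phenyl ring and where that group sits, and the compounds shown cannot separate these two changes, so neither can be credited with the step on its own. Also open, going by these compounds, is how an amine, a carboxylic acid or a methoxy group would read in place of the hydroxyl on the phenyl ring, and whether the same exchange would give a similar step on the core of compound 1.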